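Flipping One Double Bond on a Sugar-Linked Scaffold

A few compounds are considered here, and "the series" means these few. Any claim that something is new, unique, unknown or untested is made for them only; others in the source may bear on it.

Compound 1, `CC(=O)OC[C@H]1O[C@@H](n2cc(CN3C(=O)/C(=C/c4ccccc4)c4ccccc43)nn2)[C@H](OC(C)=O)[C@@H](OC(C)=O)[C@@H]1OC(C)=O`, gives 30200 nM in a functional assay on MCF7 cells (Homo sapiens) for cytotoxicity, read by sulforhodamine B assay, with a stated time of 48 h; on this read-out lower numbers stand for stronger inhibition and higher numbers for weaker inhibition.
Compound 2, `CC(=O)OC[C@H]1O[C@@H](n2cc(CN3C(=O)/C(=C/C=C/c4ccccc4)c4ccccc43)nn2)[C@H](OC(C)=O)[C@@H](OC(C)=O)[C@@H]1OC(C)=O`, gives 53200 nM.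
Compound 3, `CC(=O)OC[C@H]1O[C@@H](n2cc(CN3C(=O)/C(=C\c4ccc5ccccc5c4)c4ccccc43)nn2)[C@H](OC(C)=O)[C@@H](OC(C)=O)[C@@H]1OC(C)=O`, gives 46500 nM.

All three are weak, and the number for compound 3 sits between those of compound 1 and compound 2, with every gap among the three inside the usual scatter of this assay. Within the data shown here, the only change measured so far, a 1.8-fold higher number from compound 1 to compound 2 (0.25 log units; within the scatter), swapped one ring-bearing group for a longer chain and still moved nothing beyond the scatter.

Compound 4, `CC(=O)OC[C@H]1O[C@@H](n2cc(CN3C(=O)/C(=C/c4ccc5ccccc5c4)c4ccccc43)nn2)[C@H](OC(C)=O)[C@@H](OC(C)=O)[C@@H]1OC(C)=O`, is built from compound 3 by a change of a different kind: the two compounds have the same atoms and bonds and differ only in configuration as drawn: 1 of 6 stereo elements differ; a double bond is drawn Z in compound 3 and E in compound 4. Among the measured compounds shown here, no measured pair tests such a change of configuration, so nothing here suggests which way, if any, the number should move. Given that even a change of atoms between compound 1 and compound 2 stayed within the scatter, the expected step of a 1.0-fold lower number from compound 3 to compound 4 (0.01 log units; within the scatter) is none beyond the scatter. Compound 4 is therefore estimated at 45000 nM. Its expected range runs from 18000 nM to 110000 nM.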

Compound 4, half-maximal inhibitory concentration: 32700 nM
The estimate for compound 4 lay 1.4-fold (0.14 log units) above the measured number; measured number inside the range.
By their numbers in this assay, from the lowest: compounds 1, 4, 3 and 2 (each within the scatter of the next).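

In this assay, this pair gives the first test of configuration at this double bond, and a 1.4-fold lower number from compound 3 to compound 4 (0.15 log units; within the scatter) shows that, with naphthalen-2-yl on the bond, redrawing it from Z to E does not move the number beyond the scatter. The comparison is clean, since a single feature separates the pair: the fact that compounds 3 and 4 differ only in the configuration as drawn. With the double bond drawn as in compound 4, changing the group on the chain carbon also stays within the scatter, with a 1.6-fold lower number from compound 2 to compound 4 (0.21 log units; within the scatter) and a 1.1-fold higher number from compound 1 to compound 4 (0.03 log units; within the scatter).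

Still open, from the compounds shown here alone, is whether the same change of configuration would also stay within the scatter with phenyl or 2-phenylethenyl on the bond. Also open, going by these compounds, is whether an amine or a carboxylic acid on that chain carbon would move the number beyond the scatter.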